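The compounds below may be only part of what the source reports. "The series", "measured", "known", "first", "only" and "open" are said of these compounds alone.

Of the compounds shown here, two sharing one core have been measured in a functional assay, with a stated time of 60 min, tested at 0.1 mM; on this read-out lower numbers stand for a weaker effect and higher numbers for a stronger effect at the one concentration tested. Compound 1 `NCCCCCCNC(=O)c1c(O)c2ccccc2n(-c2ccccc2)c1=O` gives 17.5%. Compound 2 `Cn1c(=O)c(C(=O)Nc2ccccc2N)c(O)c2ccccc21` gives 13.5% in this assay; the two values lie within the usual scatter of each other, so neither can be set above the other, and both sit at the low end of the scale. Compound 3 `Nc1ccccc1NC(=O)c1c(O)c2ccccc2n(-c2ccccc2)c1=O` has not yet been measured. Its change from compound 2 is phenyl in place of methyl on an aromatic nitrogen. Going by the values given here, compound 1 carries the same phenyl on that nitrogen but a different amide part, so no measured pair isolates this change on its own. With both known values weak, the step in this assay is expected to be small, no farther than the scatter in either direction. For compound 3 the expected step is a number 1.5 percentage points higher from compound 2 to compound 3 (within the scatter). Compound 3 is estimated at 15%, between 5% and 30%.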

Compound 3, a percentage reported as activity, at one concentration (the size of the read-out at that concentration, not a potency): 16.3%
Compound 3: middle estimate off by 1.3 percentage points, on the low side, and the stated range covers the measured number.
By their numbers in this assay, from the lowest: compounds 2, 3 and 1 (each within the scatter of the next).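

In this assay, going by these compounds alone, the change of methyl to phenyl on the aromatic nitrogen gives a number 2.8 percentage points higher from compound 2 to compound 3 (within the scatter) and so offers the first direct comparison at this position: a six-carbon aromatic ring takes the place of a single carbon with no step that can be told from the scatter. On the amide-type nitrogen, the change of 6-aminohexyl to 2-aminophenyl gives a number 1.2 percentage points lower from compound 1 to compound 3 (within the scatter) and so shows that a chain and a ring at this second position also cannot be told apart on this read-out. No supporting measurement accounts for how closely these values lie.

From the compounds shown here alone, it remains open whether ethyl or benzyl on the aromatic nitrogen would move the read-out beyond the scatter. The same question stands for a shorter aminoalkyl chain or a carboxylic acid in the amide part.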